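The source may report more compounds than this note shows. Statements on the series, on what has been measured and on what is new or still open speak of the compounds shown alone.

Measured so far in an assay on isolated protein for inhibition of Rho-associated protein kinase 2 (Homo sapiens), read by HTRF; a lower number here means a stronger inhibitor, a higher number a weaker inhibitor: compound 1 `Cc1ccc2c(c1)CC(c1nc3ccc(-c4cn[nH]c4)cc3c(=O)[nH]1)CO2`, 6 nM; compound 2 `COc1ccc2c(c1)CC(c1nc3c(OC)cc(-c4cn[nH]c4)cc3c(=O)[nH]1)CO2`, 2 nM; compound 3 `COc1ccc2c(c1)CC(c1nc3c(F)cc(-c4cn[nH]c4)cc3c(=O)[nH]1)CO2`, 104 nM.

Compound 2 gives the lowest number of the three; compound 1 comes nearest, and compound 3 lies furthest away, as the step of a 52-fold higher number from compound 2 to compound 3 (1.72 log units; beyond the scatter) shows. The new compound 4 `COc1cc(-c2cn[nH]c2)cc2c(=O)[nH]c(C3COc4ccc(C)cc4C3)nc12` keeps the core of compound 2 and changes one spot: methyl in place of methoxy on an aromatic carbon. For the measured compounds named here, no measured step covers exactly this exchange. Going by the values given here, the one measured step, a 52-fold higher number from compound 2 to compound 3 (1.72 log units; beyond the scatter), sits on the other ring and was large, so it says little here. Compound 1 already carries a methyl on that ring and gives 6 nM, a higher number than compound 2, though it also differs at a second spot. Compound 4 is therefore expected to show only a small step of a 1.5-fold higher number from compound 2 to compound 4 (0.18 log units; within the scatter), estimated at 3 nM with a range from 1 nM to 10 nM.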

Compound 4, half-maximal inhibitory concentration: 5 nM
Estimate against measurement, compound 4: 1.7-fold (0.22 log units) below, and the stated range covers the measured number.
By their numbers in this assay, from the lowest: compound 2; then compounds 4 and 1 (each within the scatter of the next); then compound 3.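

Replacing methoxy with methyl on this aromatic carbon costs only modest strength in this assay, with a 2.5-fold higher number from compound 2 to compound 4 (0.40 log units; beyond the scatter), so the methoxy is not essential here. With the methyl in place, a 1.2-fold lower number from compound 1 to compound 4 (0.08 log units; within the scatter) stays within the scatter, so methoxy in place of hydrogen at the second spot gives no clear gain on this background.

From the compounds shown here alone, whether an ethyl, a chloro or an amine on this carbon would give a lower number remains open. No measurement here explains why methoxy edges out methyl at this carbon.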